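A few compounds are considered here, and "the series" means these few. Any claim that something is new, unique, unknown or untested is made for them only; others in the source may bear on it.

Compound 1 `C[C@@H]1CN(C(=O)OC(C)(C)C)CCN1c1ncc(OCC2CCN(S(C)(=O)=O)CC2)cn1` and compound 2 `C[C@@H]1CN(C(=O)OC(C)(C)C)CCN1c1ncc(OCc2ccc(S(C)(=O)=O)cc2F)cn1` share one core and differ only in the group attached to a saturated chain carbon bound to an oxygen on an aromatic ring. Going by the values given here, in a functional assay for agonist activity at Glucose-dependent insulinotropic receptor (Mus musculus), read by HTRF and cAMP accumulation, with a stated time of 45 min (a lower number here means that less compound is needed, a higher number that more compound is needed for the effect), compound 1 gives 78 nM, while compound 2 gives 34 nM, the lowest of the two numbers so far; the step is a 2.3-fold lower number from compound 1 to compound 2 (0.36 log units; beyond the scatter). Compound 3 `Cc1cnccc1COc1cnc(N2CCN(C(=O)OC(C)(C)C)C[C@H]2C)nc1` has not been measured. Its change from compound 2 is 3-methylpyridin-4-yl in place of 2-fluoro-4-(methylsulfonyl)phenyl on a saturated chain carbon bound to an oxygen on an aromatic ring. Among the compounds with values here, only the step from compound 1 to compound 2 bears on this, and it exchanged one methylsulfonyl-bearing group for another, whereas here the methylsulfonyl group and the fluorine leave altogether and a ring nitrogen enters, so that step offers limited guidance. A modest rise in the number, beyond the scatter, is expected for compound 3, roughly a 2.9-fold higher number from compound 2 to compound 3 (0.47 log units; beyond the scatter). Compound 3 is therefore estimated at 100 nM in this assay, with a range from 30 nM to 350 nM.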

Compound 3, half-maximal effective concentration: 236 nM
Estimate against measurement, compound 3: 2.4-fold (0.37 log units) below; measured number inside the range.
By their numbers in this assay, from the lowest: compound 2; then compound 1; then compound 3.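

In this assay the exchange of 2-fluoro-4-(methylsulfonyl)phenyl for 3-methylpyridin-4-yl produces a 6.9-fold higher number from compound 2 to compound 3 (0.84 log units; beyond the scatter) and is clearly larger than the earlier exchange at this position. The same group also compares poorly with 1-(methylsulfonyl)piperidin-4-yl and gives a 3.0-fold higher number from compound 1 to compound 3 (0.48 log units; beyond the scatter) in this assay, so among these three compounds the two groups carrying methylsulfonyl have the lower numbers. No measurement here explains this difference.

As far as these compounds go, because the methylsulfonyl group and the fluorine leave while a ring nitrogen and a methyl group enter in a single step, the share of each change remains unknown. The compounds shown also leave open how a plain phenyl group, or a pyridine ring bearing a methylsulfonyl group, would behave on the same saturated chain carbon.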